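Second Fluoro on the Fluorophenyl Ring: An Expected Value

The source may hold more compounds than are shown below. What is called first, only, known or untested is meant among the compounds shown, and "the series" means these compounds.

Of the compounds shown here, two with a shared core have been measured so far. Compound 1 `O=C1NC(=O)/C(=C\c2ccc(OCC(=O)N3N=C(c4ccc(F)cc4)CC3c3ccccc3)cc2)S1` gives 4200 nM in an assay on cells for inhibition of histone deacetylase 4 (Homo sapiens), read by fluorescence, with a stated time of 30 min; on this read-out lower numbers stand for stronger inhibition and higher numbers for weaker inhibition. Compound 2 `O=C1NC(=O)/C(=C\c2ccc(OCC(=O)N3N=C(c4ccc(F)cc4)CC3c3ccc(F)cc3)cc2)S1` carries a fluoro on the phenyl that compound 1 leaves bare, and in this assay compound 2 gives 1400 nM, the lowest of the two numbers. For the measured compounds named here, compound 2 therefore stands at the strong end of what has been seen, and its only neighbour is compound 1 with a higher number.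

Compound 3 `O=C1NC(=O)/C(=C\c2ccc(OCC(=O)N3N=C(c4ccc(F)cc4F)CC3c3ccc(F)cc3)cc2)S1` has not yet been measured. It differs from compound 2 by fluoro in place of hydrogen on an aromatic carbon, the new fluoro sitting ortho to a large group and meta to a fluoro group, so that a 4-fluorophenyl becomes a 2,4-difluorophenyl. Going by the values given here, the one step measured so far, a 3.0-fold lower number from compound 1 to compound 2 (0.48 log units; beyond the scatter), added a fluoro on a different ring of the core, so it bears on this change only loosely. A small move toward a lower number, or none beyond the scatter, is therefore expected; the estimated step is a 1.4-fold lower number from compound 2 to compound 3 (0.15 log units; within the scatter). For compound 3 the expected value in this assay is 1000 nM, with a range from 400 nM to 3500 nM.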

Compound 3, half-maximal inhibitory concentration: 1500 nM
The estimate for compound 3 lay 1.5-fold (0.18 log units) below the measured number; low and high end bracket the measured number.
By their numbers in this assay, from the lowest: compounds 2 and 3 (each within the scatter of the next); then compound 1.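

The step to the 2,4-difluorophenyl ring, a 1.1-fold higher number from compound 2 to compound 3 (0.03 log units; within the scatter) in this assay, means that compound 2 and compound 3 cannot be told apart in this assay. A fluoro in place of hydrogen at this place on the ring, ortho to a large group and meta to a fluoro group, is therefore accepted, but it brings no measurable gain. The earlier swap of hydrogen for fluoro on the other ring (a 3.0-fold lower number from compound 1 to compound 2 (0.48 log units; beyond the scatter)) went beyond the scatter, so the same change does not read the same at both places on the shared core, and nothing at hand explains this difference.

With fluoro the only group shown at this position, it remains open whether a chloro, a methoxy or an amine there would also leave the number within the scatter of compound 2, or would move it in either direction. As far as these compounds go, it is also open whether a fluoro at this position would read the same on a ring without the fluoro that compound 2 already carries.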